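This account rests on a few compounds, and the source may have more. Where it says the series, first, only, none or still open, it means among the compounds named here.

Measured compounds in a functional assay on the whole organism with Rattus norvegicus as the target; on this read-out higher numbers stand for an effect only at larger amounts of compound and lower numbers for an effect already at smaller amounts:
compound 1 `CC1CCC(=NNc2ccc(Cl)cc2Cl)c2ncc(C(=O)O)c(=O)n21` gives > 100 umol/kg, a limit of this assay and not a number.
compound 2 `CC1CCC(=NNc2cc([N+](=O)[O-])cc([N+](=O)[O-])c2)c2ncc(C(=O)O)c(=O)n21` gives > 100 umol/kg, a limit of this assay and not a number.
compound 3 `Cc1nc2n(c(=O)c1C(N)=O)C(C)CCC2=NNc1ccccc1` gives > 100 umol/kg, a limit of this assay and not a number.

Compound 3 stands only at a limit in this assay; no number is known for it. The two other values shown are likewise limits, so all three results sit at the limit of > 100 umol/kg in this assay, at which 3 of the 3 values shown sit. For the measured compounds named here, no step between measured compounds exists, and nothing here tells how any change on the shared core moves the read-out in this assay.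

Compound 4 `CCc1nc2n(c(=O)c1C(N)=O)C(C)CCC2=NNc1ccccc1` differs from compound 3 by methyl in place of hydrogen on a saturated chain carbon bound to an aromatic carbon. Going by the values given here, with every known value at the limit and no measured step to lean on, the change from compound 3 to compound 4 is expected to give a step that the limit leaves unreadable from compound 3 to compound 4 in this assay that stays within the usual scatter rather than in either direction. Compound 4 is therefore expected to give about 150 umol/kg in this assay, within a range from 60 umol/kg to 400 umol/kg, and most likely to be reported again only as a limit.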

Compound 4, dose for 50% inhibition: > 100 umol/kg
Compound 4: a limit, no number (the forecaster's own chance of this, stated with the estimate: 85%); the middle value does not contradict the limit.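

Compound 3 and compound 4 both give limits, not numbers, in this assay; no step can be read for methyl in place of hydrogen on a saturated chain carbon bound to an aromatic carbon. The compounds shown leave open how any change on the shared core moves the read-out.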